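The compounds below may be only part of what the source reports. "The series", "measured", "known", "first", "only" and "open" are said of these compounds alone.

Three compounds with a shared core differ only in one group on an aromatic ring. In a physicochemical assay for lipophilicity, using potentiometric titration, at pH 7.4 (on this read-out lower numbers stand for lower lipophilicity and higher numbers for higher lipophilicity), compound 1 `Fc1ccc(-c2nc(-c3ccc(-c4ccccc4)cc3)no2)cc1F` gives 4.75, compound 2 `Fc1ccc(-c2nc(-c3ccc(Br)cc3)no2)cc1F` gives 3.91 and compound 3 `Cc1ccc(-c2noc(-c3ccc(F)c(F)c3)n2)cc1` gives 4.16. Compound 3 therefore lies within the usual scatter of compound 2 and clearly under compound 1.

The next compound, compound 4 `CC(C)(C)c1ccc(-c2noc(-c3ccc(F)c(F)c3)n2)cc1`, has yet to be measured. It differs from compound 3 at a single place: tert-butyl in place of methyl on an aromatic carbon. This is tert-butyl in place of methyl on an aromatic carbon, para to a large group.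

Among the compounds with values here, no measured step involves tert-butyl, so the guidance is indirect. The nearest comparison is a larger carbon group exchanged for methyl, seen in a number 0.59 log units lower from compound 1 to compound 3 (beyond the scatter). Read in reverse, this step points to a modest rise on going from methyl to a larger carbon group. The exchange of bromo for phenyl, a number 0.84 log units lower from compound 1 to compound 2 (beyond the scatter), is of similar size, whereas a number 0.25 log units higher from compound 2 to compound 3 (within the scatter) says little about adding carbon. A modest rise beyond the scatter is thus expected, and the estimated step is a number 0.64 log units higher from compound 3 to compound 4 (beyond the scatter). For compound 4 the estimated value in this assay is 4.8, with an expected range from 4.4 to 5.3.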

Compound 4, distribution coefficient: 3.92
Beside the measured number, compound 4's estimate is 0.88 log units above it, outside the stated range (below it).
By their numbers in this assay, from the lowest: compounds 2, 4 and 3 (each within the scatter of the next); then compound 1.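

In this assay, tert-butyl in place of methyl on an aromatic carbon, para to a large group, takes the entering group from 1 heavy atom to 4 and gives a number 0.24 log units lower from compound 3 to compound 4 (within the scatter), so adding carbon at this place does not by itself move the number beyond the scatter. Tert-butyl in place of bromo gives a number 0.01 log units higher from compound 2 to compound 4 (within the scatter), which puts bromo, methyl and tert-butyl together within the scatter, whereas tert-butyl in place of phenyl gives a number 0.83 log units lower from compound 1 to compound 4 (beyond the scatter), leaving phenyl as the only one of these four groups apart from the others. No available evidence accounts for why phenyl stands apart here.

The compounds shown leave open whether a longer chain such as n-butyl would stay with bromo, methyl and tert-butyl or move toward phenyl, and where an amine or a carboxylic acid at this place would fall. They also leave open whether the gap to phenyl is tied to its being a ring, a question that a comparison with a saturated ring such as cyclohexyl could address.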